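Methoxy to trifluoromethyl, with only limits to go on

A few compounds are considered here, and "the series" means these few. Any claim that something is new, unique, unknown or untested is made for them only; others in the source may bear on it.

Measured so far in a physicochemical assay for solubility, in phosphate buffer, with a stated time of 2 h, at pH 7.4; on this read-out lower numbers stand for lower solubility and higher numbers for higher solubility
- Compound 1 `Clc1ccc(Nc2nc(-c3ccccn3)cs2)nc1` gives < 10000 nM as a limit
- Compound 2 `COc1ccc(-c2csc(Nc3ccc(Cl)cn3)n2)nc1` gives < 10000 nM as a limit

Compound 2 stands at < 10000 nM as a limit and not a number. The next compound, compound 3 `FC(F)(F)c1ccc(-c2csc(Nc3ccc(Cl)cn3)n2)nc1`, carries trifluoromethyl in place of methoxy on an aromatic carbon. For the measured compounds named here, the only measured step that bears on this change is a step that the two limits leave unreadable from compound 1 to compound 2 with methoxy in place of hydrogen on an aromatic carbon, and it offers no size to carry over. The remaining evidence is the limit of < 10000 nM in this assay, at which 2 of the 2 values shown sit, and it shows no direction. With so little to go on, a step that the limit leaves unreadable from compound 2 to compound 3 is expected to stay within the usual scatter, in no known direction. Compound 3 is estimated at 5000 nM with an expected range from 1000 nM to 10000 nM in this assay and a report as a limit is the likeliest outcome.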

Compound 3, solubility: < 10000 nM
Compound 3: a limit, no number (the forecaster's own chance of this, stated with the estimate: 90%); the middle value lies beyond the limit too.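

For the compounds shown here, compound 1, compound 2 and compound 3 are all reported as limits rather than numbers, and no step between them can be read in this assay. Whether methoxy or trifluoromethyl shifts the read-out at all stays open, since all three compounds rest on one limit: the limit of < 10000 nM in this assay, at which 3 of the 3 values shown sit.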